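Removal of the methoxy group in the thiazolidinedione pair

A few compounds are considered here, and "the series" means these few. Any claim that something is new, unique, unknown or untested is made for them only; others in the source may bear on it.

Measured so far:
compound 1, `O=C1NC(=O)C(Cc2ccc(Oc3ccc(Cl)cc3Cl)cc2)O1`, 4020 nM
compound 2, `COc1cc(Oc2ccc(Cl)cc2Cl)ccc1CC1SC(=O)NC1=O`, 1410 nM

In a functional assay for agonist activity at Free fatty acid receptor 1 (Homo sapiens), read by FLIPR, in the presence of a further agent that is not named here (a higher number here means that more compound is needed for the effect, a lower number that less compound is needed), compound 2 gives the lowest of the two numbers; compound 1 gives a number that stands beyond the scatter above it. Compound 1 differs from compound 2 in more than one place, so no single structural change can be read out of this pair.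

Compound 3, `O=C1NC(=O)C(Cc2ccc(Oc3ccc(Cl)cc3Cl)cc2)S1`, has not been measured. It differs from compound 2 in one place only: hydrogen in place of methoxy on an aromatic carbon. Among the measured compounds shown here, no pair measured so far isolates this change, so there is no basis to expect a step in either direction with confidence. For the measured compounds named here, the expected step from compound 2 to compound 3 is a 1.8-fold higher number from compound 2 to compound 3 (0.25 log units; within the scatter), a modest increase, since compound 2 gives 1410 nM and the only other number available, from compound 1, is 4020 nM. For compound 3 the estimate in this assay is 2500 nM, with a range from 900 nM to 7000 nM.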

Compound 3, half-maximal effective concentration: 101 nM
For compound 3 the middle estimate is 25-fold (1.39 log units) above the measured one, outside the stated range (below it).
By their numbers in this assay, from the lowest: compound 3; then compound 2; then compound 1.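

In this assay, hydrogen in place of methoxy on an aromatic carbon, ortho to the (2,4-dioxo-1,3-thiazolidin-5-yl)methyl group, gives a 14-fold lower number from compound 2 to compound 3 (1.14 log units; beyond the scatter) and so shows that this position is sensitive to the change. Compound 3 also separates the second change, since 2,4-dioxo-1,3-thiazolidin-5-yl in place of 2,4-dioxo-1,3-oxazolidin-5-yl gives a 40-fold lower number from compound 1 to compound 3 (1.60 log units; beyond the scatter). The difference between compound 1 and compound 2 can now be seen as two large opposing steps in one place each. Nothing measured here speaks to the reason for either step.

From the compounds shown here alone, whether the loss with methoxy extends to a smaller group at this position, such as fluorine or methyl, remains open. Also open, going by these compounds, is how a carboxylic acid would compare in place of the 2,4-dioxo-1,3-thiazolidin-5-yl group.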